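The source may report more compounds than this note shows. Statements on the series, on what has been measured and on what is new or still open speak of the compounds shown alone.

Series notes. Compound 1 `CCNc1cc(-c2ccc(NC(=O)Nc3ccc(C)cc3)cc2C)ccn1` gives 47.5% in an assay on isolated protein for inhibition of serine/threonine-protein kinase PLK1 (Homo sapiens), read by radiometric assay and 33P incorporation, with a stated time of 40 min, tested at 20 uM, in the presence of a further agent that is not named here; on this read-out higher numbers stand for more inhibition at the one concentration tested (going by the name of the read-out) and lower numbers for less inhibition. For the measured compounds named here, compound 2 `CCNc1cc(-c2ccc(NC(=O)Nc3ccc(C)cc3)cc2C(F)(F)F)ccn1` gives 42.6% in this assay; the one measured step, a number 4.9 percentage points lower from compound 1 to compound 2 (within the scatter), is trifluoromethyl in place of methyl on an aromatic carbon. On the two numbers shown, compound 2 has the lower value, but that gap is within the scatter, so no order between compound 1 and compound 2 is claimed.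

Compound 3 `CCNc1cc(-c2ccc(NC(=O)Nc3ccc(OC)cc3)cc2C(F)(F)F)ccn1` is not yet measured. Its change from compound 2 is methoxy in place of methyl on an aromatic carbon. Going by the values given here, no measured step bears on this change: the only step so far concerns a different group on a different aromatic carbon, so there is no guide from the data to the direction. With nothing pointing either way, the expected step of a number 0.6 percentage points lower from compound 2 to compound 3 (within the scatter) in this assay is none beyond the scatter, and compound 3 is estimated at 42%, range 25% to 60%.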

Compound 3, a percentage reported as inhibition, at one concentration (the size of the read-out at that concentration, not a potency): 62.1%
The estimate for compound 3 lay 20.1 percentage points below the measured number, and the stated range ends below it.
By their numbers in this assay, from the lowest: compounds 2 and 1 (each within the scatter of the next); then compound 3.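

Methoxy in place of methyl at this position gives the first step in the series beyond the scatter, a number 19.5 percentage points higher from compound 2 to compound 3 (beyond the scatter), in this assay. For the compounds shown here, the earlier step, on a different aromatic carbon, stayed within the scatter, so this change from 4-methylphenyl to 4-methoxyphenyl is the first sign that the number responds to what sits on this ring. The change adds one heavy atom and one hydrogen-bond acceptor by count, but nothing at hand ties the step to either of these or to any other cause.

On these data alone, whether the same change gives a step of similar size with methyl in place of trifluoromethyl, as in compound 1, stays open. So does the effect on this number of an amine, a hydroxyl or a longer ether such as ethoxy at this position.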